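Compound 2 to compound 4: ethylamino in place of hydroxy

This account rests on a few compounds, and the source may have more. Where it says the series, first, only, none or still open, it means among the compounds named here.

In a functional assay on A549 cells (Homo sapiens) for antiproliferative activity, read by MTT assay, with a stated time of 48 h (a higher number here means a weaker inhibitor, a lower number a stronger inhibitor), compound 2 `C=C(c1cc(OC)c(OC)c(OC)c1)c1ccc(OC)cc1NC(=O)CO` gives 20 nM as the lowest of the three measured numbers. Against that, in this assay compound 3 `C=C(c1ccc2c(c1)C=CC(C)(C)O2)c1ccc(OC)cc1NC(=O)CN` gives 60 nM and compound 1 `COc1ccc(C(=O)c2ccc(OC)c3c2C=CC(C)(C)O3)c(NC(=O)CO)c1` gives 100 nM with both numbers beyond the scatter from compound 2.

Compound 4 `C=C(c1cc(OC)c(OC)c(OC)c1)c1ccc(OC)cc1NC(=O)CNCC` departs from compound 2 in one place: ethylamino in place of hydroxy on a saturated chain carbon bound to a carbonyl carbon with ethylamino in place of hydroxy on a saturated chain carbon bound to a carbonyl carbon. Going by the values given here, no measured pair isolates this change. Among the compounds with values here, compound 3 is the only measured compound with a nitrogen on that chain carbon, but it also differs from compound 2 elsewhere, so it offers only weak guidance.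

In this assay, within the data shown here, a modest step towards a higher number, just beyond the scatter, is expected, resting on compound 3 at 60 nM as the sole nitrogen-bearing comparison. The expected step of a 2.5-fold higher number from compound 2 to compound 4 (0.40 log units; beyond the scatter) is an estimate only. For compound 4 the estimated value is 50 nM with an expected range from 15 nM to 170 nM on this reasoning.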

Compound 4, half-maximal inhibitory concentration: 260 nM
The estimate for compound 4 lay 5.2-fold (0.72 log units) below the measured number; the measured number lies above the stated range.
By their numbers in this assay, from the lowest: compound 2; then compounds 3 and 1 (each within the scatter of the next); then compound 4.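

In this assay, ethylamino in place of hydroxy on a saturated chain carbon bound to a carbonyl carbon gives a 13-fold higher number from compound 2 to compound 4 (1.11 log units; beyond the scatter) on an otherwise unchanged structure. Going by these compounds alone, this is the first reading of this position in isolation, as compound 3 also differs from compound 2 elsewhere, and it shows that the number is sensitive to this change even though both groups count the same hydrogen-bond donors and acceptors. No measurement here bears on the reason for the step.

The compounds shown do not separate the contribution of the nitrogen from that of its ethyl part. A methoxy or dimethylamino group at this place, or a longer chain on the nitrogen, would test that, and the same change on the core of compound 3 would show whether the step carries over.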